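The source may hold more compounds than are shown below. What is called first, only, known or untested is meant among the compounds shown, and "the series" means these compounds.

Measured compounds:
compound 1 `COc1ccccc1-c1cc(-c2ccc(F)cc2)c(C#N)c(OC)n1` — 75 nM
compound 2 `COc1nc(-c2ccccc2)cc(-c2ccncc2)c1C#N` — 541 nM

In an assay on isolated protein for inhibition of sulfide:quinone oxidoreductase, mitochondrial (Homo sapiens) (a lower number here means a stronger inhibitor, a higher number a weaker inhibitor), compound 1 gives 75 nM, the lower of the two numbers shown. Compound 2 gives 541 nM in this assay, a higher number, and the gap between the two lies beyond the scatter of repeated measurements. Compound 3 `COc1nc(-c2ccccn2)cc(-c2ccc(F)cc2)c1C#N` has not yet been measured. It differs from compound 1 in a single place: pyridin-2-yl in place of 2-methoxyphenyl on an aromatic carbon. For the measured compounds named here, no pair of measured compounds isolates this change, as compound 2 differs from compound 1 in two places at once, so the data give no direct guide to its direction or size. The account expects a modest step in this assay, most likely toward a higher number, of about a 2.4-fold higher number from compound 1 to compound 3 (0.38 log units; beyond the scatter) from compound 1 to compound 3. Compound 3 is therefore estimated at 180 nM, within a range from 50 nM to 700 nM.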

Compound 3, half-maximal inhibitory concentration: 14 nM
Compound 3: the middle estimate sits 13-fold (1.11 log units) above what was measured; the whole stated range lies above it.
By their numbers in this assay, from the lowest: compound 3; then compound 1; then compound 2.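

The first single-place change read at this position, on an aromatic carbon next to the ring nitrogen, runs toward stronger inhibition: in this assay, pyridin-2-yl in place of 2-methoxyphenyl gives a 5.4-fold lower number from compound 1 to compound 3 (0.73 log units; beyond the scatter) and so places compound 3 lowest of the compounds shown. The position therefore accepts a smaller ring with one hetero atom in place of the carbon-only ring bearing a methoxy group, and the number still falls beyond the scatter. Nothing measured here explains the step.

Because the ring nitrogen enters as the methoxy group leaves, these compounds cannot separate the two parts of the change. From the compounds shown here alone, how pyridin-3-yl, pyrimidin-2-yl or an amine on the pyridin-2-yl ring would read at this position also remains open.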